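This account rests on a few compounds, and the source may have more. Where it says the series, first, only, none or still open, it means among the compounds named here.

In a functional assay for inhibition, tested at 20 ug/mL (a lower number here means a weaker effect, a higher number a stronger effect of the compound at the concentration tested), two compounds have been measured so far:
compound 1 `Cc1cc(O)c(C(C)C)cc1-c1cc(-c2cccs2)c(C#N)c(=O)[nH]1` gives 26%;
compound 2 `COc1cc(-c2cc(-c3cc(C(C)C)c(O)cc3C)[nH]c(=O)c2C#N)ccc1O` gives 26%.

On these numbers compound 2 stands level with compound 1 at the digits shown, and the single measured step, no change at the digits printed from compound 1 to compound 2 (within the scatter), stayed within the scatter. Compound 3 `Cc1cc(O)c(C(C)C)cc1-c1cc(-c2ccccc2Cl)c(C#N)c(=O)[nH]1` has not yet been tested in this assay. It differs from compound 2 in one place: 2-chlorophenyl in place of 4-hydroxy-3-methoxyphenyl on an aromatic carbon. Among the measured compounds shown here, the only measured step that bears on this change is no change at the digits printed from compound 1 to compound 2 (within the scatter), which swapped a group at the same aromatic carbon and produced no shift beyond the scatter. For the measured compounds named here, the group entering compound 3 is different from both earlier groups, so that step is only a rough guide; with it as the sole evidence, compound 3 is expected to sit close to compound 2, and no change at the digits printed from compound 2 to compound 3 (within the scatter) is expected to lie within the scatter. Compound 3 is therefore estimated at 26%, with a range from 10% to 45%.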

Compound 3, a percentage reported as inhibition, at one concentration (the size of the read-out at that concentration, not a potency): 12%
Compound 3: the middle estimate sits 14 percentage points above what was measured, within the range that was stated.
By their numbers in this assay, from the lowest: compound 3; then compounds 1 and 2 (each within the scatter of the next).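

Placing 2-chlorophenyl on this aromatic carbon, opposite the ring nitrogen, gives a number 14 percentage points lower from compound 2 to compound 3 (beyond the scatter) and also a number 14 percentage points lower from compound 1 to compound 3 (beyond the scatter) in this assay, so this position does not accept every aryl group equally, a limit that the match between thiophen-2-yl and 4-hydroxy-3-methoxyphenyl had not revealed. Compared with compound 2, compound 3 loses the hydroxy and methoxy groups and gains a chlorine, and this single swap cannot separate those changes. Nothing available here explains the lower number.

As far as these compounds go, it remains open whether the chlorine itself matters, or its place on the phenyl ring. Also open, from the compounds shown here alone, is how a plain phenyl, or a phenyl carrying a carboxylic acid or a dimethylamino group, would behave on this carbon.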